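Dropping the acetoxy group: a step without precedent

The source may report more compounds than this note shows. Statements on the series, on what has been measured and on what is new or still open speak of the compounds shown alone.

Measured compounds:
compound 1, `CCC[C@@H](OC(C)=O)C1=C(Br)/C(=C/Br)OC1=O`: 1.6 ug/mL
compound 2, `CCC[C@@H](OC(C)=O)C1=C(Br)[C@@](CI)(OC)OC1=O`: 7.9 ug/mL

In a functional assay on ZR-75-1 cells (Homo sapiens) for cytotoxicity (on this read-out higher numbers stand for an effect only at larger amounts of compound and lower numbers for an effect already at smaller amounts), compound 1 gives 1.6 ug/mL, the lowest of the two numbers at hand. Among the measured compounds shown here, compound 2 gives 7.9 ug/mL in this assay, a higher number that lies beyond the scatter; the two compounds differ in more than one place, so the pair shows only that compound 1 acts at the smaller amount.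

Compound 3, `CCCCC1=C(Br)/C(=C/Br)OC1=O`, differs from compound 1 in a single place: hydrogen in place of acetoxy on a saturated chain carbon bound to a double-bonded ring carbon and a saturated chain carbon. For the measured compounds named here, no measured pair follows this kind of change, so the expectation rests on compound 1 alone. Going by the values given here, the step from compound 1 to compound 3 is expected to be modest and upward, a 1.9-fold higher number from compound 1 to compound 3 (0.27 log units; within the scatter), because the acetoxy group is the only part of compound 1 that is lost and its value of 1.6 ug/mL sets the starting point. Compound 3 is therefore estimated at 3 ug/mL in this assay, with a range from 0.8 ug/mL to 12 ug/mL.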

Compound 3, concentration for half-maximal effect: 10.2 ug/mL
The estimate for compound 3 lay 3.4-fold (0.53 log units) below the measured number; measured number inside the range.
By their numbers in this assay, from the lowest: compound 1; then compounds 2 and 3 (each within the scatter of the next).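

In this assay, hydrogen in place of acetoxy on this saturated chain carbon gives a 6.4-fold higher number from compound 1 to compound 3 (0.80 log units; beyond the scatter) and so lies beyond the usual scatter. Among the compounds shown here, this is the first comparison that isolates a single change, and it shows that, with the rest of compound 1 kept, the compound carrying acetoxy at this position acts at the smaller amount. No evidence at hand explains this difference.

The compounds shown leave open how a hydroxyl group, an amine or a longer chain on this carbon would compare with acetoxy and with hydrogen. They also leave open whether the same exchange on compound 2 would produce a step of similar direction and size.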